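Replacing the benzoyl group on the ring nitrogen with a sulfonyl group

The source may hold more compounds than are shown below. What is called first, only, known or untested is meant among the compounds shown, and "the series" means these compounds.

Measured so far:
- compound 1, `COc1cc(C2=NNC(c3ccc(Cl)cc3)C2)ccc1O`, gives 90.2%.
- compound 2, `COc1cc(C2=NN(C(=O)c3ccccc3)C(c3ccc(Cl)cc3)C2)ccc1O`, gives 78.2%.

Both numbers come from an ADME assay on HepG2 cells (Homo sapiens) for cytotoxicity, read by MTT assay, with a stated time of 24 h, tested at 25 uM; on this read-out lower numbers stand for a stronger effect and higher numbers for a weaker effect at the one concentration tested. For the measured compounds named here, compound 2 stands lowest of the two, and its only neighbour is compound 1, which gives a number that is higher by a number 12 percentage points lower from compound 1 to compound 2 (beyond the scatter). The next compound, compound 3, `COc1cc(C2=NN(S(=O)(=O)c3ccc(C)cc3)C(c3ccc(Cl)cc3)C2)ccc1O`, is not yet measured. It differs from compound 2 in one place: (4-methylphenyl)sulfonyl in place of benzoyl on an amine nitrogen in a ring. Going by the values given here, no measured step shows what swapping benzoyl for (4-methylphenyl)sulfonyl does; the one known step, a number 12 percentage points lower from compound 1 to compound 2 (beyond the scatter), concerns benzoyl in place of hydrogen and is only modest. For compound 3 a change of a number 3.2 percentage points lower from compound 2 to compound 3 (within the scatter) from compound 2 is therefore expected, that is, nothing clearly beyond the scatter. The estimate for compound 3 is 75%, with a range from 55% to 92%.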

Compound 3, a percentage reported as activity, at one concentration (the size of the read-out at that concentration, not a potency): 64.1%
The estimate for compound 3 lay 10.9 percentage points above the measured number, within the range that was stated.
By their numbers in this assay, from the lowest: compound 3; then compound 2; then compound 1.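

Filling the ring nitrogen with benzoyl had shown only that a group there can lower the number in this assay. With (4-methylphenyl)sulfonyl in place of benzoyl, the result is a number 14.1 percentage points lower from compound 2 to compound 3 (beyond the scatter), so the identity of the group at this position counts, and not only the presence of one. Set against the free ring nitrogen, the same sulfonyl group gives a number 26.1 percentage points lower from compound 1 to compound 3 (beyond the scatter), yet no measurement at hand explains either step.

The compounds shown leave open whether the lower number goes with the sulfonyl link or with the methyl on its ring. Also open, from the compounds shown here alone, is how a small acetyl or methanesulfonyl group, or a chain ending in an amine or a carboxylic acid, would read on this same nitrogen.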